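The source may report more compounds than this note shows. Statements on the series, on what has been measured and on what is new or still open speak of the compounds shown alone.

Values in an ADME assay on MRC5 cells (Homo sapiens) for antiproliferative activity, read by fluorescence and resazurin assay, with a stated time of 68 h (on this read-out higher numbers stand for an effect only at larger amounts of compound and lower numbers for an effect already at smaller amounts), so far
Compound 1 `Cc1ccc(-c2cc(C(=O)Nc3cccnc3)c3cc(Br)ccc3n2)cc1` gives 21000 nM
Compound 2 `Cc1ccc(-c2cc(C(=O)Nc3cccnc3)c3cc(Cl)ccc3n2)cc1` gives 21000 nM
Compound 3 `Cc1ccc(-c2cc(C(=O)NCCCN(C)C)c3cc(Cl)ccc3n2)cc1` gives 6000 nM

Compound 3 holds the lowest number of the three, while compound 1 and compound 2 show the same value. The next change leads to compound 4 `Cc1ccc(-c2cc(C(=O)NCCN3CCCCC3)c3cc(Cl)ccc3n2)cc1` and reads piperidin-1-yl in place of (dimethylamino)methyl on a saturated chain carbon, two bonds along the chain from an amide-type nitrogen in full. Piperidin-1-yl thus takes the place of (dimethylamino)methyl on a saturated chain carbon, two bonds along the chain from an amide-type nitrogen.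

Going by the values given here, only one measured step touches the group on that nitrogen: a 3.5-fold lower number from compound 2 to compound 3 (0.54 log units; beyond the scatter) for 3-(dimethylamino)propyl in place of pyridin-3-yl. The other, no change at the digits printed from compound 1 to compound 2 (within the scatter) for chloro in place of bromo, concerns a different place. Among the compounds with values here, no measured step swaps one such amine chain for another, so the data give no direct size. A small move, not clearly beyond the scatter, is expected in this assay here. The expected move is a 1.2-fold lower number from compound 3 to compound 4 (0.08 log units; within the scatter) on this estimate. Compound 4 is estimated at 5000 nM with an expected range from 2000 nM to 13000 nM in this read-out.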

Compound 4, half-maximal effective concentration: 7000 nM
Compound 4: middle estimate off by 1.4-fold (0.15 log units), on the low side; the measured number falls inside the stated range.
By their numbers in this assay, from the lowest: compounds 3 and 4 (each within the scatter of the next); then compounds 1 and 2 (each within the scatter of the next).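

In this assay the change to piperidin-1-yl gives a 1.2-fold higher number from compound 3 to compound 4 (0.07 log units; within the scatter) and so does not separate the open 3-(dimethylamino)propyl chain from the 2-(piperidin-1-yl)ethyl chain. Measured against the pyridin-3-yl amide, the new chain gives a 3.0-fold lower number from compound 2 to compound 4 (0.48 log units; beyond the scatter) and the earlier chain gives a 3.5-fold lower number from compound 2 to compound 3 (0.54 log units; beyond the scatter), so the shift from compound 2 is now seen with two different groups on the amide-type nitrogen, not with 3-(dimethylamino)propyl alone. Nothing available on these compounds accounts for these numbers.

Still open, on these data alone, is how a morpholine ring, a primary amine or a longer chain on the amide-type nitrogen would read in this assay. Also open, as far as these compounds go, is whether 2-(piperidin-1-yl)ethyl reads the same with bromo in place of chloro on the shared core.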